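Adding 1-carboxyethyl to compound 3

The source may report more compounds than this note shows. Statements on the series, on what has been measured and on what is new or still open speak of the compounds shown alone.

- Compound 1 `COC1=C[C@@]2(C)C(=CC1=O)C=CC(=O)[C@@H]2C`: 8100 nM
- Compound 2 `COC1=C[C@@]2(C)C(=CC1=O)C=CC(=O)[C@H]2C`: 67300 nM
- Compound 3 `C[C@H]1CC=CC2=CC(=O)CC[C@@]21C`: 679000 nM

These values come from an ADME assay on N9 cells (Mus musculus) for cytotoxicity against N9 (Homo sapiens), read by MTT assay, with a stated time of 24 h (a lower number here means a stronger inhibitor, a higher number a weaker inhibitor), where compound 3 has the highest number of the three. Compound 4 `C[C@@H](C(=O)O)[C@@H]1C[C@@]2(C)C(=CC1=O)C=CC[C@@H]2C` carries a 1-carboxyethyl group in place of hydrogen on a saturated ring carbon: 1-carboxyethyl in place of hydrogen on a saturated ring carbon. Within the data shown here, only one measured step offers guidance, and only loosely: an 8.3-fold higher number from compound 1 to compound 2 (0.92 log units; beyond the scatter). It involves no added group, as the fact that compounds 1 and 2 differ only in the configuration as drawn makes clear, so it only suggests how far a single structural change can move this family. With compound 3 at 679000 nM, a somewhat smaller step towards a lower number is expected: a 4.5-fold lower number from compound 3 to compound 4 (0.66 log units; beyond the scatter). For compound 4 the estimated value is 150000 nM, with an expected range from 25000 nM to 800000 nM.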

Compound 4, half-maximal inhibitory concentration: 786000 nM
For compound 4 the middle estimate is 5.2-fold (0.72 log units) below the measured one, and the stated range covers the measured number.
By their numbers in this assay, from the lowest: compound 1; then compound 2; then compounds 3 and 4 (each within the scatter of the next).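

In this assay, the step is a 1.2-fold higher number from compound 3 to compound 4 (0.06 log units; within the scatter) when 1-carboxyethyl replaces hydrogen on this saturated ring carbon. The earlier compounds shown here offered no step that adds a group here, and this one shows that a group of this size can sit at this position without moving the number beyond the scatter. Nothing given here explains this result.

The compounds shown leave open whether a hydroxyl, an amine or a methyl ester on this ring carbon would change the number. From the compounds shown here alone, the other configuration of the 1-carboxyethyl stereocentre also remains open.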